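Piperidine to neopentylpiperazine at the diaminopyrimidine position

The source may report more compounds than this note shows. Statements on the series, on what has been measured and on what is new or still open speak of the compounds shown alone.

Compound 3 `Cc1nc(N2CCC(O)CC2)nc2ccc(NC(=O)COc3ccc(Cl)cc3)cc12` gives the lowest number shown in a functional assay on CHO-K1 cells for antagonist activity at melanin-concentrating hormone receptor 1 (Homo sapiens), read by inositol phosphate accumulation (a lower number here means a stronger inhibitor, a higher number a weaker inhibitor), namely 163 nM. Compound 2 `Cc1nc(N2CCC(C)(O)CC2)nc2ccc(NC(=O)COc3ccc(Cl)cc3)cc12` gives 827 nM, and a 5.1-fold lower number from compound 2 to compound 3 (0.71 log units; beyond the scatter). Compound 1 `Cc1nc(N2CCN(S(C)(=O)=O)CC2)nc2ccc(NC(=O)COc3ccc(Cl)cc3)cc12` is reported only as a limit, > 10000 nM, so the limit of > 10000 nM in this assay, at which 1 of the 3 values shown sits, applies to it. Compound 4 `Cc1nc(N2CCN(CC(C)(C)C)CC2)nc2ccc(NC(=O)COc3ccc(Cl)cc3)cc12` carries 4-neopentylpiperazin-1-yl in place of 4-hydroxypiperidin-1-yl on an aromatic carbon. Among the compounds with values here, the steps that bear on this are an at least 61-fold lower number from compound 1 to compound 3 (1.78 log units; beyond the scatter) and an at least 12-fold lower number from compound 1 to compound 2 (1.08 log units; beyond the scatter), both of which move away from a piperazine toward a piperidine with a hydroxyl and lower the number strongly. Compound 4 reverses that move, returning to a piperazine without a hydroxyl, so a large rise in this assay is expected, a 12-fold higher number from compound 3 to compound 4 (1.09 log units; beyond the scatter). Compound 4 is therefore estimated at 2000 nM, with a range of 300 nM to 10000 nM.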

Compound 4, half-maximal inhibitory concentration: 246 nM
Compound 4: the middle estimate sits 8.1-fold (0.91 log units) above what was measured; the whole stated range lies above it.
By their numbers in this assay, from the lowest: compounds 3 and 4 (each within the scatter of the next); then compound 2. At a limit, above all of these: compound 1.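

In this assay, the hydroxyl is not required at this position, as 4-neopentylpiperazin-1-yl shows a 1.5-fold higher number from compound 3 to compound 4 (0.18 log units; within the scatter) and a 3.4-fold lower number from compound 2 to compound 4 (0.53 log units; beyond the scatter). A piperazine is therefore compatible with this position, and the group on its ring nitrogen matters, with an at least 40-fold lower number from compound 1 to compound 4 (1.60 log units; beyond the scatter). The value for compound 1 is a limit: the limit of > 10000 nM in this assay, at which 1 of the 4 values shown sits.

Still open, on these data alone, is how far this holds for other groups on that nitrogen, such as a methyl, a longer chain or a carboxylic acid. Also open, as far as these compounds go, is whether a neopentyl group carried on a piperidine gives a similar number.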